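From 3-bromobenzyl to 2,4-dichlorobenzyl at the assay limit

The source may report more compounds than this note shows. Statements on the series, on what has been measured and on what is new or still open speak of the compounds shown alone.

In a functional assay on MCF cells (Homo sapiens) for antiproliferative activity, with a stated time of 72 h (a lower number here means a stronger inhibitor, a higher number a weaker inhibitor), compound 1 `OC[C@H]1O[C@@H](n2cnc3c(NCc4ccccc4Cl)ncnc32)[C@H](O)[C@@H]1O` gives > 166000 nM as a limit and not a number. Compound 2 `OC[C@H]1O[C@@H](n2cnc3c(NCc4ccccc4Br)ncnc32)[C@H](O)[C@@H]1O`, which carries bromo in place of chloro on an aromatic carbon, gives > 166000 nM as a limit too. Compound 3 `OC[C@H]1O[C@@H](n2cnc3c(NCc4cccc(Br)c4)ncnc32)[C@H](O)[C@@H]1O` gives > 166000 nM as a limit as well, so it has no exact value and stands level with the other two only in carrying the same limit.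

The next compound, compound 4 `OC[C@H]1O[C@@H](n2cnc3c(NCc4ccc(Cl)cc4Cl)ncnc32)[C@H](O)[C@@H]1O`, has 2,4-dichlorophenyl in place of 3-bromophenyl on a saturated chain carbon bound to a nitrogen on an aromatic ring and has yet to be measured.

The measured changes give no size to build on. They are a step that the two limits leave unreadable from compound 1 to compound 2 and a step that the two limits leave unreadable from compound 1 to compound 3 and a step that the two limits leave unreadable from compound 2 to compound 3 in this assay as they stand. What compound 1, compound 2 and compound 3 do share is the limit of > 166000 nM in this assay, at which 3 of the 3 values shown sit, and that is the whole basis for the expectation here.

No step beyond the usual scatter is expected, and the estimated change is a number no higher from compound 3 to compound 4 (the limit leaves the size open) with no direction favoured. Compound 4 is estimated at 166000 nM with an expected range from 90000 nM to 300000 nM and will probably be reported as a limit again.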

Compound 4, half-maximal inhibitory concentration: 127000 nM
Compound 4: the middle estimate sits 1.3-fold (0.12 log units) above what was measured; measured number inside the range.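

Compound 4 is the first of the four to give an exact number instead of a limit in this assay, so a benzyl group on the nitrogen can register in this assay, while the other compounds stay at a shared ceiling: the limit of > 166000 nM in this assay, at which 3 of the 4 values shown sit.

Going by these compounds alone, the steps that can be read are an at least 1.3-fold lower number from compound 3 to compound 4 (0.11 log units; that floor lies within the scatter), an at least 1.3-fold lower number from compound 2 to compound 4 (0.11 log units; that floor lies within the scatter) and an at least 1.3-fold lower number from compound 1 to compound 4 (0.11 log units; that floor lies within the scatter), and the last is the simplest to interpret, as the only change is chloro in place of hydrogen on an aromatic carbon. Going by these compounds, each of these is only a floor inside the scatter, so the exact number does not yet establish a real gain from the second chlorine, and the true size of each step stays unknown.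

The compounds shown leave open whether both chlorines are needed, which a 4-chlorobenzyl group would help to settle. They also leave open whether anything other than a halogen at this place, such as an amine or a carboxylic acid on the ring, or a longer chain in place of the single carbon of the benzyl group, would move the number well beyond the scatter.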